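The compounds below may be only part of what the source reports. "The series", "measured", "known", "first", "only" and "open" are said of these compounds alone.

Measured so far in the assay:

Compound 1, `O=c1[nH]c(=O)n(COCCO)cc1[N+](=O)[O-]`: > 200000 nM, which is only a limit of the assay.
Compound 2, `O=c1ccn(COCCO)c(=O)[nH]1`: > 200000 nM, again only a limit.
Compound 3, `Nc1nc(=O)n(COCCO)cc1[N+](=O)[O-]`: > 200000 nM, once more only a limit.

All three were tested in an ADME assay on L1210/0 cells (Mus musculus) for cytotoxicity, with a stated time of 48 h; on this read-out higher numbers stand for weaker inhibition and lower numbers for stronger inhibition. The change from compound 1 to compound 2 is hydrogen in place of nitro on an aromatic carbon, and the step it made, a step that the two limits leave unreadable from compound 1 to compound 2, cannot be read because of the limit of > 200000 nM in this assay, at which 3 of the 3 values shown sit. Compound 3 shares with compound 1 a core whose difference is not broken down here.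

Compound 4, `Nc1ccn(COCCO)c(=O)n1`, has not yet been measured. It differs from compound 3 by hydrogen in place of nitro on an aromatic carbon. This is the same kind of change as that from compound 1 to compound 2, not the same: in compound 3 the carbon is ortho to an amino group (1 heavy atom), whereas in compound 1 it is ortho to a group of 1 heavy atom.

The step expected from compound 3 to compound 4 is a step that the limit leaves unreadable from compound 3 to compound 4, resting on the unreadable step that the two limits leave unreadable from compound 1 to compound 2 and on (the limit of > 200000 nM in this assay, at which 3 of the 3 values shown sit). Compound 4 is therefore expected at about 300000 nM, most likely again only a limit, within 100000 nM to 1000000 nM.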

Compound 4, half-maximal inhibitory concentration: > 200000 nM
Compound 4 was reported as a limit; the forecaster's own chance of this, stated with the estimate: 85%; the middle value lies beyond the limit too.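

Compound 3 and compound 4 are both reported only as limits, so no step can be read between them, because neither gives a number to compare: the limit of > 200000 nM in this assay, at which 4 of the 4 values shown sit.

The compounds shown leave open whether hydrogen in place of nitro on an aromatic carbon changes inhibition in this assay at all, and how strong any of these four compounds is.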